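The compounds below may be only part of what the source reports. "The series", "measured", "known", "first", "only" and "open" are said of these compounds alone.

Measured compounds:
compound 1 `Cc1ccccc1Cn1cc(COc2ccc3c(=O)ccoc3c2)nn1` — 15300 nM
compound 2 `O=c1ccoc2cc(OCc3cn(Cc4ccc(Cl)cc4Cl)nn3)ccc12` — 80600 nM
compound 3 `CC(C)(C)c1ccc(Cn2cc(COc3ccc4c(=O)ccoc4c3)nn2)cc1` — 17600 nM

In a functional assay on HeLa cells (Homo sapiens) for cytotoxicity, read by MTT assay, with a stated time of 48 h (on this read-out higher numbers stand for weaker inhibition and lower numbers for stronger inhibition), compound 1 holds the lowest number of the three; compound 3 sits within the scatter of it, while compound 2 sits clearly higher, with a step of a 5.3-fold higher number from compound 1 to compound 2 (0.72 log units; beyond the scatter).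

Compound 4 `N#Cc1ccc(Cn2cc(COc3ccc4c(=O)ccoc4c3)nn2)cc1` is not yet measured. It differs from compound 1 by 4-cyanophenyl in place of 2-methylphenyl on a saturated chain carbon bound to an aromatic nitrogen. Among the compounds with values here, the only step that bears on this change is the one from compound 1 to compound 2, where another aryl swap at the same place gave a 5.3-fold higher number from compound 1 to compound 2 (0.72 log units; beyond the scatter); the pair compound 1 and compound 3, which also swap the aryl there, show no difference beyond the scatter. A small step upward is therefore expected, a 1.4-fold higher number from compound 1 to compound 4 (0.16 log units; within the scatter), and compound 4 is estimated at 22000 nM (range 9000 nM to 60000 nM).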

Compound 4, half-maximal inhibitory concentration: > 100000 nM
Compound 4 ended at the assay's limit (the forecaster's own chance of this, stated with the estimate: 5%); at least 4.5-fold (0.65 log units) between middle value and limit.
By their numbers in this assay, from the lowest: compounds 1 and 3 (each within the scatter of the next); then compound 2. At a limit, above all of these: compound 4.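

In this assay compound 4 gives > 100000 nM, a limit of the assay and not a number. On a saturated chain carbon bound to an aromatic nitrogen, 4-cyanophenyl in place of 2-methylphenyl gives an at least 6.5-fold higher number from compound 1 to compound 4 (0.81 log units; beyond the scatter), and cyano in place of tert-butyl on an aromatic carbon gives an at least 5.6-fold higher number from compound 3 to compound 4 (0.75 log units; beyond the scatter), so a single group on that aryl ring can decide whether any cytotoxicity stays in range. The remaining step, an at least 1.2-fold higher number from compound 2 to compound 4 (0.09 log units; that floor lies within the scatter), cannot be read as a difference.

Open, from the compounds shown here alone, is whether an amine or a carboxylic acid on that aromatic carbon behaves like cyano or like tert-butyl. Also open, going by these compounds, is what a longer chain in place of the saturated chain carbon would do.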